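Urea-linked quinoline series: shortening the linker in compound 4

The compounds below may be only part of what the source reports. "The series", "measured", "known", "first", "only" and "open" are said of these compounds alone.

Measured so far:
compound 1, `COc1cc(NC(C)CCCNC(=O)NNC(=O)Nc2ccc(Br)cc2)c2ncccc2c1`, 51000 nM
compound 2, `COc1cc(NC(C)CCCNC(=O)NNC(=O)Nc2ccc(O)cc2)c2ncccc2c1`, 95000 nM
compound 3, `COc1cc(NC(C)CCCNC(=O)NNC(=O)Nc2ccc(F)cc2)c2ncccc2c1`, 104000 nM

In a functional assay on L1210 cells (Mus musculus) for inhibition, read by MTT assay, with a stated time of 72 h (a lower number here means a stronger inhibitor, a higher number a weaker inhibitor), compound 3 gives the highest of the three numbers. Against compound 2 the gap is a 1.1-fold higher number from compound 2 to compound 3 (0.04 log units; within the scatter); against compound 1 it is a 2.0-fold higher number from compound 1 to compound 3 (0.31 log units; beyond the scatter), the only step that clears the scatter. Compound 4, `COc1cc(NC(C)CCCNC(=O)Nc2cccc(O)c2)c2ncccc2c1`, changes the other end of the chain: 3-hydroxyphenyl in place of ((4-fluorophenyl)carbamoyl)amino on an amide-type nitrogen. Among the compounds with values here, no measured step touches this part of the molecule; the steps between compounds 1, 2 and 3 all swap substituents on the distal ring and are small, so they give no direction for a change that removes that ring's carbamoyl-amino extension altogether. The expected step is therefore a 1.3-fold lower number from compound 3 to compound 4 (0.11 log units; within the scatter), with a wide range. For compound 4 the estimate in this assay is 80000 nM, between 30000 nM and 200000 nM.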

Compound 4, half-maximal inhibitory concentration: 25000 nM
Estimate against measurement, compound 4: 3.2-fold (0.51 log units) above, and the stated range ends above it.
By their numbers in this assay, from the lowest: compound 4; then compounds 1, 2 and 3 (each within the scatter of the next, the first and the last beyond it).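

In this assay the group on the amide-type nitrogen moves the number further than the distal ring substituents do: a 4.2-fold lower number from compound 3 to compound 4 (0.62 log units; beyond the scatter) and a 3.8-fold lower number from compound 2 to compound 4 (0.58 log units; beyond the scatter) are both larger than any step among compounds 1, 2 and 3. The step from the bromo compound is smaller, a 2.0-fold lower number from compound 1 to compound 4 (0.31 log units; beyond the scatter), yet it still lies beyond the scatter, so compound 4 is the strongest inhibitor of the four. No evidence on why this change lowers the number is available.

The compounds shown do not separate loss of the carbamoyl-amino unit from the placement of the hydroxy group. A 3-aminophenyl or 3-bromophenyl group on the same nitrogen remains an open comparison.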